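A few compounds are considered here, and "the series" means these few. Any claim that something is new, unique, unknown or untested is made for them only; others in the source may bear on it.

The measured compounds in an assay on isolated protein for agonist activity at Bile acid receptor (Homo sapiens), read by TR-FRET, with a stated time of 3 h, in the absence of a further agent; a lower number here means that less compound is needed, a higher number that more compound is needed for the effect:
compound 1 `O=C(O)c1cccc(NC(=O)c2ccc(Oc3ccccc3)cc2)c1` gives 97 nM;
compound 2 `Cc1ccc(NC(=O)c2ccc(Oc3ccccc3)cc2)cc1C(=O)O` gives 127 nM;
compound 3 `O=C(O)c1cccc(NC(=O)c2ccc(OCc3ccccc3)cc2)c1` gives 135 nM.

Compound 2 differs from compound 1 by methyl in place of hydrogen on an aromatic carbon, and this change gave a 1.3-fold higher number from compound 1 to compound 2 (0.12 log units; within the scatter). Compound 3 differs from compound 1 in its core by benzyl in place of phenyl on an oxygen on an aromatic ring, with a 1.4-fold higher number from compound 1 to compound 3 (0.14 log units; within the scatter). Compound 4 `Cc1cccc(COc2ccc(C(=O)Nc3cccc(C(=O)O)c3)cc2)c1` has not yet been measured in this assay. It differs from compound 3 by methyl in place of hydrogen on an aromatic carbon. This is the same kind of change as from compound 1 to compound 2, but not the same: in compound 2 the methyl sits ortho to a carboxy group and para to a large group, whereas in compound 4 it sits meta to a large group. Because the earlier step of this kind was a 1.3-fold higher number from compound 1 to compound 2 (0.12 log units; within the scatter) and the core change was a 1.4-fold higher number from compound 1 to compound 3 (0.14 log units; within the scatter), only a small step is expected for compound 4, a 1.2-fold higher number from compound 3 to compound 4 (0.07 log units; within the scatter). Compound 4 is therefore estimated at 160 nM, between 70 nM and 350 nM.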

Compound 4, half-maximal effective concentration: 259 nM
Compound 4: middle estimate off by 1.6-fold (0.21 log units), on the low side, within the range that was stated.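

Carried onto the core of compound 3, methyl in place of hydrogen on an aromatic carbon gave a 1.9-fold higher number from compound 3 to compound 4 (0.28 log units; within the scatter), and in this assay this step does not differ from the earlier one: the same change on two cores in this assay, a 1.3-fold higher number (0.12 log units; within the scatter) from compound 1 to compound 2 and a 1.9-fold higher number (0.28 log units; within the scatter) from compound 3 to compound 4, 1.5-fold (0.17 log units) apart, within the scatter of two such steps. Only the combined difference, 3-methylbenzyl in place of phenyl on an oxygen on an aromatic ring, gave a 2.7-fold higher number from compound 1 to compound 4 (0.43 log units; beyond the scatter), a modest step that is the sum of a core change and a methyl and cannot be assigned to either alone. Two pairs show that the change carried across these two cores without a detectable difference, but they do not show a general rule, since the methyl stands in a different place in each pair and both steps are small.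

As far as these compounds go, whether a chlorine, a methoxy or an amine in the place of this methyl would behave alike remains open. So does the effect of a longer chain in place of the benzyl group, or of a tetrazole in place of the carboxylic acid.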